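The source may hold more compounds than are shown below. What is called first, only, known or untested is meant among the compounds shown, and "the series" means these compounds.

Measured so far in a functional assay on HeLa cells (Homo sapiens) for antiproliferative activity, with a stated time of 48 h; on this read-out higher numbers stand for weaker inhibition and lower numbers for stronger inhibition:
Compound 1 `C=C(Br)C(=O)Nc1ccc(/C=C/C(=O)c2ccc(Cl)cc2)cc1` gives 1600 nM
Compound 2 `C=C(Br)C(=O)Nc1ccc(/C=C/C(=O)c2ccc(Cl)c(Cl)c2)cc1` gives 3200 nM
Compound 3 `C=C(Br)C(=O)Nc1ccc(/C=C/C(=O)c2cccc(OC)c2)cc1` gives 700 nM

Compound 1 stands close to compound 2 and apart from compound 3. One comparison shows a 2.0-fold higher number from compound 1 to compound 2 (0.30 log units; within the scatter), so those two cannot be told apart. The other shows a 2.3-fold lower number from compound 1 to compound 3 (0.36 log units; beyond the scatter), a modest move.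

Compound 4 `C=C(Br)C(=O)Nc1ccc(/C=C/C(=O)c2ccc(OCC)cc2)cc1` has not yet been measured. It differs from compound 1 at a single place: ethoxy in place of chloro on an aromatic carbon. The new group sits para to a large group.

Going by the values given here, no measured step makes this exact swap. The closest is the move from compound 1 to compound 3, which also removes the chloro and brings in a smaller relative of ethoxy, though at a different place on the ring. That move gave a 2.3-fold lower number from compound 1 to compound 3 (0.36 log units; beyond the scatter), and starting from compound 2 the same kind of swap gave a 4.6-fold lower number from compound 2 to compound 3 (0.66 log units; beyond the scatter). Both point toward lower numbers, but neither is a direct precedent, so only part of that size is expected to carry over in this assay. The expected change is small and downward, an estimated 1.6-fold lower number from compound 1 to compound 4 (0.20 log units; within the scatter), and it may not clear the usual scatter. For compound 4 the expected value is 1000 nM, with an estimated range from 450 nM to 2400 nM.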

Compound 4, half-maximal inhibitory concentration: 750 nM
Beside the measured number, compound 4's estimate is 1.3-fold (0.12 log units) above it, within the range that was stated.
By their numbers in this assay, from the lowest: compounds 3 and 4 (each within the scatter of the next); then compounds 1 and 2 (each within the scatter of the next).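

In this assay, the position para to a large group, which carries chloro in compound 1, also accepts ethoxy, a group of more heavy atoms that adds a hydrogen-bond acceptor, and the swap gives a 2.1-fold lower number from compound 1 to compound 4 (0.33 log units; beyond the scatter) with the shift modest in size but clear of the usual scatter. The earlier steps shown here could not show this, since one added a second chloro while the others replaced the substituted phenyl as a whole and so changed where the ring carried its groups; here, one group is exchanged for another at the same place, with the rest of the molecule untouched. Nothing available on these compounds accounts for the lower number.

A single swap cannot show whether the shift follows from the oxygen attached to the ring or from the two-carbon chain behind it, and a hydroxyl group, a propoxy chain or an amine at this same position would help to separate those readings. Going by these compounds, how far this position tolerates something much bulkier, such as a phenyl ring, also remains open.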